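Swapping the amino-methoxy ring for a trifluoromethyl ring

This account rests on a few compounds, and the source may have more. Where it says the series, first, only, none or still open, it means among the compounds named here.

Among the three measured compounds, compound 3 `COc1ccc(/C=C/C(=O)Nc2cc(C(=O)c3cc(OC)c(OC)c(OC)c3)cc(OC)c2OC)cc1N` gives the highest number in a functional assay on PC-3 cells (Homo sapiens) for cytotoxicity, read by MTT assay, with a stated time of 72 h (a lower number here means a stronger inhibitor, a higher number a weaker inhibitor), at 11100 nM. Compound 1 `COc1cc(C(=O)c2cc(OC)c(OC)c(OC)c2)cc(NC(=O)/C=C/c2cc(OC)c(OC)c(OC)c2)c1OC` gives 4800 nM in this assay, and compound 2 `COc1ccc(/C=C/C(=O)Nc2cc(C(=O)c3cc(OC)c(OC)c(OC)c3)cc(OC)c2OC)cc1OC` gives 5400 nM. Both differ from compound 3 only on the ring at the far end of the chain: a 2.3-fold higher number from compound 1 to compound 3 (0.36 log units; beyond the scatter), and a 2.1-fold higher number from compound 2 to compound 3 (0.31 log units; beyond the scatter). Among the compounds with values here, the one step that leaves that ring's amino absent, a 1.1-fold higher number from compound 1 to compound 2 (0.05 log units; within the scatter), is within the scatter.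

Compound 4 `COc1cc(C(=O)c2cc(OC)c(OC)c(OC)c2)cc(NC(=O)/C=C/c2ccc(C(F)(F)F)cc2)c1OC` changes that same ring again: 4-(trifluoromethyl)phenyl in place of 3-amino-4-methoxyphenyl on a double-bonded chain carbon bound to a double-bonded chain carbon. Within the data shown here, no measured step tests a trifluoromethyl anywhere, so the only guidance is that compound 3 sits at the weak end and that the two ring changes leading to it each cost a modest amount. Removing the amino might recover part of that, but replacing the methoxy with a group never seen here could go either way. The expected step is therefore small, toward a lower number, and near the edge of the scatter: a 1.9-fold lower number from compound 3 to compound 4 (0.27 log units; within the scatter). Compound 4 is estimated at 6000 nM in this assay, within a range from 2000 nM to 18000 nM.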

Compound 4, half-maximal inhibitory concentration: 4200 nM
Compound 4: the middle estimate sits 1.4-fold (0.15 log units) above what was measured, within the range that was stated.
By their numbers in this assay, from the lowest: compounds 4, 1 and 2 (each within the scatter of the next); then compound 3.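

In this assay, moving to 4-(trifluoromethyl)phenyl at this place on the chain gives a clear gain over the 3-amino-4-methoxyphenyl ring (a 2.6-fold lower number from compound 3 to compound 4 (0.42 log units; beyond the scatter)), which leaves compound 3 as the weakest of the four compounds and the only one that stands apart from the rest. The new ring cannot be told apart from either methoxy-bearing ring, as the steps from the 3,4-dimethoxyphenyl ring (a 1.3-fold lower number from compound 2 to compound 4 (0.11 log units; within the scatter)) and from the 3,4,5-trimethoxyphenyl ring (a 1.1-fold lower number from compound 1 to compound 4 (0.06 log units; within the scatter)) both show, so this position tolerates a ring with no methoxy at all, and one whose group counts no hydrogen-bond donors or acceptors performs level with rings that do carry acceptors. Why the amino-bearing ring falls behind while such different rings sit level cannot be said from anything available here.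

A plain phenyl, or a ring carrying a chlorine or a nitrile, would show whether the trifluoromethyl contributes anything at this place or whether any of these rings simply serves equally well. A ring carrying an amino and no methoxy would show whether the amino alone accounts for the weaker number of compound 3.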